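A few compounds are considered here, and "the series" means these few. Any claim that something is new, unique, unknown or untested is made for them only; others in the source may bear on it.

Measured so far in a functional assay on A498 cells (Homo sapiens) for inhibition, with a stated time of 48 h; a lower number here means a stronger inhibitor of growth, a higher number a weaker inhibitor of growth

compound 1 `COc1ccccc1/C=C/C(=O)c1c(O)cc2occc2c1OC` gives 46000 nM
compound 2 `COc1c(C(=O)/C=C/c2ccc(Cl)cc2)c(O)c(Br)c2occc12` gives 3920 nM
compound 3 `C=CCc1c(O)c(C(=O)/C=C/c2ccccc2)c(OC)c2ccoc12` gives 1740 nM

Compound 3 has the lowest number of the three, beyond the scatter from both compound 2 and compound 1. Compound 4 `C=CCc1c(O)c(C(=O)/C=C/c2ccc(Cl)cc2)c(OC)c2ccoc12` follows from compound 3 with chloro in place of hydrogen on an aromatic carbon, para to a large group, so that phenyl becomes 4-chlorophenyl (chloro in place of hydrogen on an aromatic carbon). Within the data shown here, no measured pair isolates this change. Compound 2 also carries 4-chlorophenyl, but it differs from compound 4 elsewhere and cannot fix the size of the step. In this assay, no step beyond the scatter is expected, only a slight lean toward a lower number (a 1.2-fold lower number from compound 3 to compound 4 (0.09 log units; within the scatter)). For compound 4 the estimated value is 1400 nM (expected range 550 nM to 3500 nM).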

Compound 4, concentration for 50% growth inhibition: 2770 nM
The estimate for compound 4 lay 2.0-fold (0.30 log units) below the measured number; measured number inside the range.
By their numbers in this assay, from the lowest: compounds 3, 4 and 2 (each within the scatter of the next, the first and the last beyond it); then compound 1.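

In this assay, among these compounds, 4-chlorophenyl in place of phenyl gives a 1.6-fold higher number from compound 3 to compound 4 (0.20 log units; within the scatter) and so is the first reading of this change, para to a large group, with no step beyond the scatter. With 4-chlorophenyl held in common, allyl in place of bromo on an aromatic carbon gives a 1.4-fold lower number from compound 2 to compound 4 (0.15 log units; within the scatter) and likewise stays inside the scatter. Nothing available explains either step.

Open, on these data alone, is whether a fluoro, an amine or a carboxylic acid in place of that chloro would move the number beyond the scatter. Also open, as far as these compounds go, is whether a longer chain in place of allyl would do so.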